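Swapping a sulfonyl for an amide at the chain end

A few compounds are considered here, and "the series" means these few. Any claim that something is new, unique, unknown or untested is made for them only; others in the source may bear on it.

Three compounds share one core and differ only at the end of a short chain. Compound 1 `C/N=C(/S)[C@@]1(c2cccnc2)CCCC[C@@H]1CCO` carries a hydroxy there; in a functional assay (aorta) with Rattus norvegicus as the target (a higher number here means a weaker inhibitor, a lower number a stronger inhibitor), compound 1 gives 1700 nM. Compound 2 `C/N=C(/S)[C@@]1(c2cccnc2)CCCC[C@@H]1CCNc1ccccc1` carries an anilino instead, and compound 2 gives 3 nM. Compound 3 `C/N=C(/S)[C@@]1(c2cccnc2)CCCC[C@@H]1CCNS(=O)(=O)c1cccs1` carries a ((thiophen-2-yl)sulfonyl)amino, and compound 3 gives 1 nM, the lowest of the three numbers. The steps are a 570-fold lower number from compound 1 to compound 2 (2.75 log units; beyond the scatter), a 1700-fold lower number from compound 1 to compound 3 (3.23 log units; beyond the scatter) and a 3.0-fold lower number from compound 2 to compound 3 (0.48 log units; beyond the scatter): replacing the hydroxy brought the large gains, while exchanging the group on the nitrogen moved the number only modestly.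

Compound 4 `C/N=C(/S)[C@@]1(c2cccnc2)CCCC[C@@H]1CCNC(=O)C(C)C` differs from compound 3 in one place: isopropylcarbonyl in place of (thiophen-2-yl)sulfonyl on an amine nitrogen. Among the compounds with values here, no measured compound carries an amide at this position, and the nearest guide is the modest step of a 3.0-fold lower number from compound 2 to compound 3 (0.48 log units; beyond the scatter), which shows that two quite different groups on this nitrogen give numbers that are not far apart. An isopropylcarbonyl has fewer heavy atoms and no ring; a modest rise in this assay is expected, not a return toward compound 1. The estimated step is a 4.0-fold higher number from compound 3 to compound 4 (0.60 log units; beyond the scatter). Compound 4 is therefore expected to give about 4 nM, with a likely range from 1 nM to 20 nM.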

Compound 4, concentration for 90% inhibition: 300 nM
Compound 4: the middle estimate sits 75-fold (1.88 log units) below what was measured; measured number outside the range, above it.
By their numbers in this assay, from the lowest: compound 3; then compound 2; then compound 4; then compound 1.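

In this assay the group on this amine nitrogen matters far more than the earlier modest exchange on it suggested, as isopropylcarbonyl gives a 300-fold higher number from compound 3 to compound 4 (2.48 log units; beyond the scatter) and also a 100-fold higher number from compound 2 to compound 4 (2.00 log units; beyond the scatter) and both of these steps are large. A nitrogen at the chain end is therefore not enough on its own to give a low number: the (isopropylcarbonyl)amino keeps only a small part of the gain seen with the other two nitrogen groups, with a 5.7-fold lower number from compound 1 to compound 4 (0.75 log units; beyond the scatter) as a modest step in place of the large ones. Among these few compounds, the two lowest numbers belong to groups that carry an aromatic ring, while the isopropylcarbonyl has no ring.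

From the compounds shown here alone, it remains open whether the rise comes from the carbonyl or from the isopropyl, a question that a benzoyl group, with an aromatic ring on the carbonyl, or an isopropylsulfonyl group could help to settle. Nothing at hand bears on why these steps are so large.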